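A few compounds are considered here, and "the series" means these few. Any claim that something is new, unique, unknown or untested is made for them only; others in the source may bear on it.

Working notes on the series. Within the data shown here, in an ADME assay on L02 cells (Homo sapiens) for inhibition, read by CCK-8 assay, with a stated time of 48 h (a higher number here means a weaker inhibitor of growth, a lower number a stronger inhibitor of growth), compound 2 (`CCN1CCN(c2ccc(Nc3ncc(Cl)c(Nc4ccccc4C)n3)cc2)CC1`) gives 970 nM as the only true number so far. Compound 1 (`Cc1ccccc1Nc1nc(Nc2ccccc2)ncc1Cl`) gives > 100000 nM as a limit of the assay. Among the measured compounds shown here, the one measured step (an at least 100-fold lower number from compound 1 to compound 2 (2.01 log units; beyond the scatter)) is large and has a limit at one end. It records the 4-ethylpiperazin-1-yl group arriving on an aromatic carbon, not that group being exchanged for another, so it sets no size for the next change. Compound 3 (`Cc1ccccc1Nc1nc(Nc2ccc(N3CCCN(C)CC3)cc2)ncc1Cl`) carries 4-methyl-1,4-diazepan-1-yl in place of 4-ethylpiperazin-1-yl on an aromatic carbon with the same atoms joined differently. In this assay the reference point is compound 2 (970 nM). For this exchange the shift is expected to stay within the scatter. The expected step is small (a 1.0-fold higher number from compound 2 to compound 3 (0.01 log units; within the scatter)). For compound 3 the estimate is 1000 nM with an expected range from 350 nM to 3000 nM in this assay.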

Compound 3, concentration for 50% growth inhibition: 1240 nM
The estimate for compound 3 lay 1.2-fold (0.09 log units) below the measured number; measured number inside the range.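

Among these compounds, the exchange of the six-membered ring of 4-ethylpiperazin-1-yl for the seven-membered ring of 4-methyl-1,4-diazepan-1-yl is the first exchange at this position, and in this assay it gives a 1.3-fold higher number from compound 2 to compound 3 (0.11 log units; within the scatter). The large step on adding a group to this aromatic carbon is therefore not confined to one ring, since the second group gives an at least 80-fold lower number from compound 1 to compound 3 (1.90 log units; beyond the scatter). The full size of that step stays open, as compound 1 stands at a limit of the assay and not at a number: the limit of > 100000 nM in this assay, at which 1 of the 3 values shown sits.

Compound 3 changes ring size and the ethyl-to-methyl group on the ring nitrogen together, so the two changes remain unseparated. Also open, on these data alone, is whether a morpholin-4-yl ring or an open-chain dimethylamino group on this carbon would give a number close to those of compound 2 and compound 3.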